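Methoxy in place of fluoro on compound 2

The source may hold more compounds than are shown below. What is called first, only, known or untested is meant among the compounds shown, and "the series" means these compounds.

Among the measured compounds shown here, only two values are known so far. In an ADME assay on MCF7-DOX cells (Homo sapiens) for cytotoxicity, read by MTT assay, with a stated time of 48 h (a lower number here means a stronger inhibitor, a higher number a weaker inhibitor), compound 1 `COc1cc(O)c(C(=O)/C=C/c2ccc(N3CCNCC3)cc2)c(OC)c1` gives 67500 nM and compound 2 `COc1cc(OC)c(C(=O)/C=C/c2cccc(F)c2)c(O)c1CC=C(C)C` gives 45400 nM, and these two lie within the usual scatter of each other. Compound 3 `COc1cccc(/C=C/C(=O)c2c(OC)cc(OC)c(CC=C(C)C)c2O)c1` carries methoxy in place of fluoro on an aromatic carbon, meta to a large group (methoxy in place of fluoro on an aromatic carbon). For the measured compounds named here, no measured pair shows this change, so no step beyond the scatter is expected in this assay, in either direction. The estimated change is a 1.1-fold lower number from compound 2 to compound 3 (0.05 log units; within the scatter). For compound 3 the expected value is 40000 nM, with an estimated range of 18000 nM to 85000 nM.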

Compound 3, half-maximal inhibitory concentration: 49200 nM
The estimate for compound 3 lay 1.2-fold (0.09 log units) below the measured number, and the stated range covers the measured number.
By their numbers in this assay, from the lowest: compounds 2, 3 and 1 (each within the scatter of the next).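

In this assay, putting methoxy in place of fluoro on an aromatic carbon, meta to a large group, gives a 1.1-fold higher number from compound 2 to compound 3 (0.03 log units; within the scatter). This first measured pair shows that, at this position, the added heavy atom and hydrogen-bond acceptor leave the number within the scatter. Nothing at hand gives a reason for this result.

Going by these compounds, whether an amine or a carboxylic acid at this same place would move the number beyond the scatter remains open. So does the effect of a longer chain on the oxygen of the methoxy group.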